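The source may hold more compounds than are shown below. What is called first, only, known or untested is meant among the compounds shown, and "the series" means these compounds.

Compound 1 `N#Cc1c(N)nc(SCc2ncn[nH]2)c(C#N)c1-c1ccc(OCC2CC2)cc1`: 338 nM
Compound 2 `CCOc1ccc(-c2c(C#N)c(N)nc(SCc3ncc[nH]3)c2C#N)cc1`: 8.2 nM
Compound 3 `C=CCOc1ccc(-c2c(C#N)c(N)nc(SCC(N)=O)c2C#N)cc1`: 323 nM

All three compounds share a core and were tested in an assay on CHO cells for displacement of a labelled ligand from adenosine receptor A1 (Homo sapiens), read by scintillation counting, with a stated time of 90 min; a lower number here means a stronger inhibitor, a higher number a weaker inhibitor. Among them compound 1 gives the highest number, 338 nM, yet compound 3, at 323 nM, sits so close that the two cannot be told apart within the scatter. Compound 2, at 8.2 nM, lies far below compound 1, well beyond the scatter. For the measured compounds named here, no pair of these measured compounds differs in a single place, so no individual step can be read from them.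

Compound 4 `COC(=O)c1cccc(CSc2nc(N)c(C#N)c(-c3ccc(OCC4CC4)cc3)c2C#N)c1` has not yet been measured in this assay. It differs from compound 1 in one place: 3-(methoxycarbonyl)phenyl in place of 1H-1,2,4-triazol-5-yl on a saturated chain carbon bound to a sulfur. The change swaps a small nitrogen-rich ring for a larger benzene ring bearing an ester, while the rest of the molecule stays untouched. Nothing measured here isolates the effect of this swap, so the expectation rests on the spread of the three numbers and on the nature of the new group. Compound 4 is expected to give about 50 nM, with a likely range from 10 nM to 250 nM. The step of a 6.8-fold lower number from compound 1 to compound 4 (0.83 log units; beyond the scatter) is expected to run toward a lower number by a middling amount, somewhat beyond the scatter.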

Compound 4, inhibition constant: 66 nM
Estimate against measurement, compound 4: 1.3-fold (0.12 log units) below; the measured number falls inside the stated range.
By their numbers in this assay, from the lowest: compound 2; then compound 4; then compounds 3 and 1 (each within the scatter of the next).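

In this assay, exchanging (1H-1,2,4-triazol-5-yl)methyl for 3-(methoxycarbonyl)benzyl on the sulfur gives a 5.1-fold lower number from compound 1 to compound 4 (0.71 log units; beyond the scatter), so the group held on this saturated chain carbon can by itself move the number beyond the scatter. The earlier compounds shown here could not show this, since no two of them differed in only one place. The step also shows that, with the rest of compound 1 unchanged, a larger group built on a carbon-only aromatic ring and carrying no hydrogen-bond donor is compatible with a lower number, so the triazole ring and its hydrogen-bond donor are not needed to reach this level.

No measurement here explains why the number falls. A single step also cannot separate the contribution of the benzene ring from that of its ester, leaving open whether a plain benzyl group would give a similar number, and whether a carboxylic acid or an amide in place of the methyl ester would keep the gain.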